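Aryl sulfone variation on the shared core

The compounds below may be only part of what the source reports. "The series", "measured", "known", "first", "only" and "open" are said of these compounds alone.

Measured compounds in an assay on isolated protein for displacement of a labelled ligand from metabotropic glutamate receptor 5 (Homo sapiens), with a stated time of 60 min, tested at 1 uM; on this read-out lower numbers stand for less inhibition and higher numbers for more inhibition at the one concentration tested (going by the name of the read-out):
- compound 1, `Cc1ccc(S(=O)(=O)c2cnc3ccc(F)cc3c2N2CCC(C)CC2)cc1C`: 92%
- compound 2, `CC1CCN(c2c(S(=O)(=O)c3ccc(Cl)c(Cl)c3)cnc3ccc(F)cc23)CC1`: 91%
- compound 3, `CC1CCN(c2c(S(=O)(=O)c3cccc(C#N)c3)cnc3ccc(F)cc23)CC1`: 93%

Compound 3 holds the highest of the three numbers, though all three sit within the scatter of one another: a number 1 percentage points higher from compound 1 to compound 3 (within the scatter) and a number 2 percentage points higher from compound 2 to compound 3 (within the scatter), and between the other two a number 1 percentage points lower from compound 1 to compound 2 (within the scatter). Going by the values given here, on these numbers no compound can be set above another; every variation of the aryl group on the sulfonyl sulfur tried so far leaves the read-out at the same high level.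

Compound 4, `Cc1ccc(S(=O)(=O)c2cnc3ccc(F)cc3c2N2CCC(C)CC2)cc1`, is not yet measured. It differs from compound 3 as follows: 4-methylphenyl in place of 3-cyanophenyl on a sulfonyl sulfur. All three measured steps bear on this change, since each swaps one aryl group for another on the sulfonyl sulfur, and each stayed within the scatter. A fourth such swap is therefore expected to produce no step beyond the scatter in this assay, in either direction, with a small allowance for the smaller group entering. The estimate for compound 4 is 90%, with a range from 80% to 96%. This estimate means an expected step of a number 3 percentage points lower from compound 3 to compound 4 (within the scatter).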

Compound 4, a percentage reported as inhibition, at one concentration (the size of the read-out at that concentration, not a potency): 91%
Compound 4: the middle estimate sits 1 percentage points below what was measured; the range from low to high includes it.
By their numbers in this assay, from the lowest: compounds 2, 4, 1 and 3 (each within the scatter of the next).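

Compound 4 adds the smallest change in the set: in this assay, hydrogen in place of methyl on an aromatic carbon gives a number 1 percentage points lower from compound 1 to compound 4 (within the scatter), so the 3,4-dimethylphenyl group and the 4-methylphenyl group on the sulfonyl sulfur cannot be told apart. The comparisons with the other two aryl groups read the same way, with a number 2 percentage points lower from compound 3 to compound 4 (within the scatter) and no change at the digits printed from compound 2 to compound 4 (within the scatter), so an aryl group made of carbon alone, with no hydrogen-bond acceptor, stands level with 3-cyanophenyl and 3,4-dichlorophenyl in this read-out. No measurement in hand bears on why the read-out stays level across these aryl groups.

Still open, from the compounds shown here alone, is whether a carboxylic acid or an aminomethyl group on the phenyl ring, or a saturated cyclohexyl group in its place, would keep the read-out at this level. All four numbers come from one concentration, so any difference in potency among these aryl groups also remains open, as does the effect of changing the shared core.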